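Swapping isopropyl for acetyl on a urea-linked aryl ring

The source may hold more compounds than are shown below. What is called first, only, known or untested is meant among the compounds shown, and "the series" means these compounds.

The measured compounds so far:
compound 1, `CC(C)c1ccccc1NC(=O)N[C@H](C)c1ccccc1`, 101%
compound 2, `CC(C)c1ccccc1NC(=O)N[C@@H](C)c1ccccc1`, 96%
compound 3, `CCOC(=O)c1ccc(NC(=O)N[C@@H](C)c2ccccc2)cc1`, 97%

In an ADME assay on the whole organism with Oryza sativa as the target, tested at 1 uM (a higher number here means a weaker effect of the compound at the concentration tested, a lower number a stronger effect), compound 2 gives 96%. Among the measured compounds shown here, its number lies within the scatter of both neighbours: compound 3 gives 97%, and the step of a number 5 percentage points lower from compound 1 to compound 2 (within the scatter) is the only one in which two compounds differ in a single place, because of the fact that compounds 1 and 2 differ only in the configuration as drawn. That step changed nothing beyond the scatter.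

Compound 4, `CC(=O)c1ccccc1NC(=O)N[C@@H](C)c1ccccc1`, has not been measured. Compared with compound 2 the change is acetyl in place of isopropyl on an aromatic carbon. For the measured compounds named here, no measured step touches this part of the shared core, so there is no direct guide. Going by the values given here, the one step that exists, from compound 1 to compound 2, stayed inside the scatter, and compound 3, which carries a different group on the other ring, also sits near compound 2. The expected step in this assay is therefore no change at the digits printed from compound 2 to compound 4 (within the scatter), that is none beyond the scatter. Compound 4 is estimated at 96%, with a range from 84% to 106%.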

Compound 4, a percentage reported as activity, at one concentration (the size of the read-out at that concentration, not a potency): 97%
Estimate against measurement, compound 4: 1 percentage points below; low and high end bracket the measured number.
By their numbers in this assay, from the lowest: compounds 2, 3, 4 and 1 (each within the scatter of the next).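

At this aromatic carbon, ortho to a large group, this assay records a number 1 percentage points higher from compound 2 to compound 4 (within the scatter) when acetyl takes the place of isopropyl. The earlier compounds shown here left this part of the shared core untested, and the result now shows that the read-out stays within the scatter even though acetyl brings an oxygen, a double bond outside aromatic rings and a hydrogen-bond acceptor that isopropyl lacks. Nothing available explains why the read-out holds at this place.

As far as these compounds go, whether an amine, a carboxylic acid or a longer chain on this aromatic carbon would move the number beyond the scatter stays open. Also open, from the compounds shown here alone, is whether acetyl would give the same picture with the stereocentre at the saturated chain carbon drawn R, as in compound 1.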